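Adding a Methyl to a Valine-like Side Chain

The compounds below may be only part of what the source reports. "The series", "measured", "known", "first", "only" and "open" are said of these compounds alone.

Compound 2 `CC(C)C1NC(=O)N(C2CCCC2)C1=O` is a small ring-containing amide. In a functional assay on WI-38 cells (Homo sapiens) for inhibition (on this read-out lower numbers stand for stronger inhibition and higher numbers for weaker inhibition), compound 2 gives > 100000 nM, which is a limit of the assay rather than a number. Compound 1 `CCC(C)C1NC(=O)N(C2CCCC2)C1=O` carries methyl in place of hydrogen on a saturated chain carbon, two bonds along the chain from a saturated ring carbon. In this assay compound 1 gives > 100000 nM, again a limit. The step is therefore a step that the two limits leave unreadable from compound 2 to compound 1. Compound 3 `CC(C)C(NC(=O)n1nnc2ccccc21)C(=O)NC1CCCC1` has a different core; the difference between the two cores is not broken down here. In this assay compound 3 gives >= 100000 nM, also a limit. These readings rest on the limit of > 100000 nM in this assay, at which 2 of the 3 values shown sit, and (the limit of >= 100000 nM in this assay, at which 1 of the 3 values shown sits).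

Compound 4 `CCC(C)C(NC(=O)n1nnc2ccccc21)C(=O)NC1CCCC1` introduces (methyl in place of hydrogen on a saturated chain carbon, three bonds along the chain from an amide-type nitrogen and a carbonyl carbon). This is the same kind of change, but its place differs: two bonds along the chain from a saturated ring carbon in the earlier pair, three bonds from an amide-type nitrogen and a carbonyl carbon here. The expected step is a number no higher from compound 3 to compound 4 (the limit leaves the size open), set beside a step that the two limits leave unreadable from compound 2 to compound 1. This expectation rests on compound 3 giving >= 100000 nM. Compound 4 is estimated at 100000 nM.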

Compound 4, half-maximal inhibitory concentration: > 100000 nM
Compound 4: no number, only a limit; the forecaster's own chance of this, stated with the estimate: 85%; the middle value sits exactly at the limit.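

Compound 3 and compound 4 each give only a limit of the assay, not a number, so no step can be read between them. The compounds shown leave open whether adding the methyl changes inhibition at all.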